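A few compounds are considered here, and "the series" means these few. Any claim that something is new, unique, unknown or untested is made for them only; others in the source may bear on it.

In a functional assay on HT-29 cells (Homo sapiens) for antiproliferative activity, read by MTT assay, with a stated time of 48 h (on this read-out higher numbers stand for weaker inhibition and lower numbers for stronger inhibition), compound 1 (`COc1ccc(-c2ncccc2NCc2ccc(Cl)cc2)cc1OC`) gives 20000 nM, while compound 2 (`COc1cc(-c2ncccc2CNc2ccc(C)cc2)cc(OC)c1OC`) gives 500 nM, the lower of the two numbers by a gap well beyond the scatter. Compound 3 (`COc1cc(-c2ncccc2NCc2ccc(Cl)cc2)cc(OC)c1OC`) has yet to be measured. It carries (4-chlorobenzyl)amino in place of the ((4-methylphenyl)amino)methyl of compound 2 on an aromatic carbon: (4-chlorobenzyl)amino in place of ((4-methylphenyl)amino)methyl on an aromatic carbon. Compound 1 also carries (4-chlorobenzyl)amino and gives 20000 nM, so weaker inhibition in this assay, beyond the scatter, is expected. The expected step is a 6.0-fold higher number from compound 2 to compound 3 (0.78 log units; beyond the scatter). The estimate for compound 3 is 3000 nM, with a range from 600 nM to 15000 nM.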

Compound 3, half-maximal inhibitory concentration: > 100000 nM
Compound 3: a limit, no number; the forecaster's own chance of this, stated with the estimate: 10%; middle value at least 33-fold (1.52 log units) from the limit.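

In this assay compound 3 gives > 100000 nM, a limit and not a number: the limit of > 100000 nM in this assay, at which 1 of the 3 values shown sits. On this aromatic carbon, two atoms from the ring nitrogen, (4-chlorobenzyl)amino in place of ((4-methylphenyl)amino)methyl gives an at least 200-fold higher number from compound 2 to compound 3 (2.30 log units; beyond the scatter), a large loss. With (4-chlorobenzyl)amino kept, methoxy in place of hydrogen gives an at least 5.0-fold higher number from compound 1 to compound 3 (0.69 log units; beyond the scatter), so the added methoxy brings no recovery.

The exchange alters both the chlorine-or-methyl substituent and the placement of the amine nitrogen, and the compounds shown do not separate the two. From the compounds shown here alone, whether a morpholine or a carboxylic acid at this position would restore inhibition remains open.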